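This account rests on a few compounds, and the source may have more. Where it says the series, first, only, none or still open, it means among the compounds named here.

Compound 1, `CCCS(=O)(=O)Nc1ccc(F)c(C(=O)c2n[nH]c3ncc(-c4ccccc4O)cc23)c1F`: 9%
Compound 2, `CCCS(=O)(=O)Nc1ccc(F)c(C(=O)c2n[nH]c3ncc(-c4ccc(N(C)C)cc4)cc23)c1F`: 2.5%

In an assay for binding affinity to dual specificity mitogen-activated protein kinase kinase 4 (Homo sapiens), read by KINOMEscan, tested at 100 nM (on this read-out higher numbers stand for a weaker effect at the one concentration tested and lower numbers for a stronger effect), compound 2 and compound 1 lie within the scatter of each other, so neither stands apart. Compound 3, `CCCS(=O)(=O)Nc1ccc(F)c(C(=O)c2n[nH]c3ncc(-c4cc(Cl)cc(Cl)c4)cc23)c1F`, carries 3,5-dichlorophenyl in place of 4-(dimethylamino)phenyl on an aromatic carbon. Going by the values given here, the one measured step at this same position, a number 6.5 percentage points lower from compound 1 to compound 2 (within the scatter), stayed within the scatter, which is the only guide here. A change of the group at this place is therefore expected to move the read-out little, with a number 5.5 percentage points higher from compound 2 to compound 3 (within the scatter) expected to stay within the scatter. Compound 3 is estimated at 8%, between 1% and 30%.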

Compound 3, a percentage reported as activity, at one concentration (the size of the read-out at that concentration, not a potency): 73%
Beside the measured number, compound 3's estimate is 65 percentage points below it; the whole stated range lies below it.
By their numbers in this assay, from the lowest: compounds 2 and 1 (each within the scatter of the next); then compound 3.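

Putting 3,5-dichlorophenyl on this aromatic carbon in place of 4-(dimethylamino)phenyl gives a number 70.5 percentage points higher from compound 2 to compound 3 (beyond the scatter) in this assay, and putting it there in place of 2-hydroxyphenyl gives a number 64 percentage points higher from compound 1 to compound 3 (beyond the scatter). The group at this place can therefore weaken the effect greatly, even though the earlier pair showed no difference beyond the scatter. Nothing available explains this change. On these data alone, it remains open whether a phenyl ring with a single chlorine would read like compound 3, and how a pyridine ring or a morpholine at this place would read.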